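This account rests on a few compounds, and the source may have more. Where it says the series, first, only, none or still open, it means among the compounds named here.

Measured so far in an ADME assay on BJ cells (Homo sapiens) for cytotoxicity, with a stated time of 72 h; a lower number here means that less compound is needed, a higher number that more compound is needed for the effect
Compound 1 (`CCc1ccc(-c2nc3c(c(C)nn3-c3ccccc3)c(-c3ccccc3O)c2C#N)cc1`) gives > 20000 nM as a limit
Compound 2 (`CCc1ccc(-c2nc3c(c(C)nn3-c3ccccc3)c(-c3ccccc3C)c2C#N)cc1`) gives > 20000 nM as a limit

Compound 2 shows > 20000 nM as a limit of the assay, so it has no exact place on the scale. The whole picture so far is the limit of > 20000 nM in this assay, at which 2 of the 2 values shown sit, and nothing finer. For the measured compounds named here, the one measured step is a step that the two limits leave unreadable from compound 1 to compound 2 and it concerns methyl in place of hydroxy on an aromatic carbon. It offers no size to carry over.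

Compound 3 (`CCc1ccc(-c2nc3c(c(C)nn3-c3ccccc3)c(-c3ccccc3C(F)(F)F)c2C#N)cc1`) has trifluoromethyl in place of methyl on an aromatic carbon, ortho to a large group, which turns 2-methylphenyl into 2-(trifluoromethyl)phenyl. Going by the values given here, no measured step tests this exchange directly. With compound 2 at > 20000 nM as a limit, compound 3 is expected to show no step beyond the scatter in this assay and will most likely be reported as a limit too. The expected change is a step that the limit leaves unreadable from compound 2 to compound 3 and it should not be read as a real difference. Compound 3 is estimated at 25000 nM with an expected range from 12000 nM to 50000 nM in this estimate.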

Compound 3, half-maximal effective concentration: > 20000 nM
Compound 3: a limit, no number (the forecaster's own chance of this, stated with the estimate: 85%); the middle value does not contradict the limit.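

The steps among compound 1, compound 2 and compound 3 cannot be read, since each result is a limit and not a number: the limit of > 20000 nM in this assay, at which 3 of the 3 values shown sit.

The compounds shown leave open how far hydroxy, methyl and trifluoromethyl differ in this assay, and whether any exchange at this place would give a measurable number there.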